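The source may report more compounds than this note shows. Statements on the series, on what has been measured and on what is new or still open speak of the compounds shown alone.

Compound 3 `Cc1cc(C(=O)Nc2cc(-c3c(-c4ccc(F)c(C)c4)nc4cccnn34)ccn2)ccn1` is the least soluble of the three compounds measured here in a physicochemical assay for solubility, read by HPLC, at pH 6.8; a higher number here means a more soluble compound, a lower number a less soluble compound: compound 3 gives 0.15 ug/mL, while compound 2 `Cc1cc(-c2nc3cccnn3c2-c2ccnc(NC(=O)c3ccncc3)c2)ccc1F` gives 0.75 ug/mL and compound 1 `Cc1cc(-c2nc3cccnn3c2-c2ccnc(NC(=O)c3ccc(C)[n+]([O-])c3)c2)ccc1F` gives 2.4 ug/mL. The steps among them run downward toward compound 3: a 3.2-fold lower number from compound 1 to compound 2 (0.51 log units; beyond the scatter), a 16-fold lower number from compound 1 to compound 3 (1.20 log units; beyond the scatter) and a 5.0-fold lower number from compound 2 to compound 3 (0.70 log units; beyond the scatter). Compound 4 `Cc1ccc(C(=O)Nc2cc(-c3c(-c4ccc(F)c(C)c4)nc4cccnn34)ccn2)cn1` has not yet been measured in this assay. It differs from compound 3 in one place, (6-methylpyridin-3-yl in place of 2-methylpyridin-4-yl on a carbonyl carbon); the two compounds hold the same atoms, joined differently. Among the measured compounds shown here, no measured step matches this change. The step of a 5.0-fold lower number from compound 2 to compound 3 (0.70 log units; beyond the scatter) introduced the methyl that both compound 3 and compound 4 carry, so that step is already spent, and the remaining steps concern a different group on the carbonyl carbon. With nothing to point either way, compound 4 is expected to stay close to compound 3, with a 1.3-fold higher number from compound 3 to compound 4 (0.12 log units; within the scatter) lying within the scatter. Compound 4 is therefore estimated at 0.2 ug/mL, in a range from 0.07 ug/mL to 0.6 ug/mL.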

Compound 4, solubility: 0.38 ug/mL
Beside the measured number, compound 4's estimate is 1.9-fold (0.28 log units) below it, and the stated range covers the measured number.
By their numbers in this assay, from the lowest: compound 3; then compounds 4 and 2 (each within the scatter of the next); then compound 1.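

In this assay, among the compounds shown here, the change at the carbonyl carbon gives a 2.5-fold higher number from compound 3 to compound 4 (0.40 log units; beyond the scatter), so a rearrangement that leaves the atoms unchanged can alone produce a step beyond the scatter, which no earlier step could show. The methyl-bearing group also does not always part from the pyridin-4-yl group by more than the scatter, as a 2.0-fold lower number from compound 2 to compound 4 (0.30 log units; within the scatter) shows; the 2-methylpyridin-4-yl group did so, but the 6-methylpyridin-3-yl group does not. The oxygen-bearing group of compound 1 remains clearly separated, with a 6.3-fold lower number from compound 1 to compound 4 (0.80 log units; beyond the scatter).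

No measurement shown explains why the two isomeric groups differ. On these data alone, it remains open whether a methyl placed elsewhere on the pyridine, or an amine or a carboxylic acid on this ring, would follow the same trend.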